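From compound 1 to compound 3: a chain-end change

The source may report more compounds than this note shows. Statements on the series, on what has been measured and on what is new or still open speak of the compounds shown alone.

- compound 1 `Cc1ccc(CCCCOc2ccc3c(O)c([N+](=O)[O-])c(=O)oc3c2)cc1` gives 2500 nM
- compound 2 `Cc1cc(OCCCOc2ccccc2)cc2oc(=O)c([N+](=O)[O-])c(O)c12` gives 5200 nM

In a functional assay on ileum (Cavia porcellus) for antagonist activity (on this read-out lower numbers stand for stronger inhibition and higher numbers for weaker inhibition), compound 1 stands lowest of the two numbers (2500 nM). Its nearest neighbour, compound 2, lies higher (5200 nM), a gap beyond the usual scatter.

The next compound to be read is compound 3 `COc1ccc(OCCCOc2ccc3c(O)c([N+](=O)[O-])c(=O)oc3c2)cc1`. Relative to compound 1 it has 4-methoxyphenoxy in place of 4-methylbenzyl on a saturated chain carbon, three bonds along the chain from an oxygen on an aromatic ring. Within the data shown here, no measured pair differs in one place only, so the data offer no direct guide to this change. In this assay a slight shift toward weaker inhibition is expected, though none beyond the scatter. The expected step is small (a 1.4-fold higher number from compound 1 to compound 3 (0.15 log units; within the scatter)). For compound 3 the estimated value is 3500 nM, with an expected range from 1200 nM to 10000 nM.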

Compound 3, half-maximal inhibitory concentration: > 4000 nM
Compound 3 gave a limit, no number (the forecaster's own chance of this, stated with the estimate: 5%); middle value at least 1.1-fold (0.05 log units) from the limit.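

In this assay compound 3 gives > 4000 nM, which is a limit of the assay and not a number. Among these compounds, this is the first single-place comparison: 4-methoxyphenoxy in place of 4-methylbenzyl on a saturated chain carbon, three bonds along the chain from an oxygen on an aromatic ring, gives an at least 1.6-fold higher number from compound 1 to compound 3 (0.20 log units; that floor lies within the scatter). The change therefore shows no gain in inhibition at this position, but the size of any loss cannot be read, since the floor of the step stays within the scatter.

The compounds shown leave open whether the result follows from the methoxy group or from the oxygen that joins the ring to the chain, as the two enter together. They also leave open how an amine or a carboxylic acid at this chain end, or a longer chain, would read.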